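The source may report more compounds than this note shows. Statements on the series, on what has been measured and on what is new or still open speak of the compounds shown alone.

Series notes. Three compounds share a core: compound 1 `N#Cc1ccc(/C=C2\CN(S(=O)(=O)c3ccc(F)cc3)C/C(=C\c3ccccc3F)C2=O)cc1`, compound 2 `COc1cc(/C=C2\CN(S(=O)(=O)c3ccc(F)cc3)C/C(=C\c3ccccc3F)C2=O)cc(OC)c1OC` and compound 3 `CC(=O)Nc1ccc(S(=O)(=O)N2C/C(=C\c3ccc(C#N)cc3)C(=O)/C(=C/c3ccccc3F)C2)cc1`. In an ADME assay on L02 cells (Homo sapiens) for cytotoxicity, read by MTT assay, with a stated time of 24 h (on this read-out higher numbers stand for weaker inhibition and lower numbers for stronger inhibition), compound 1 gives 21900 nM, compound 2 gives 17600 nM and compound 3 gives 14400 nM. The change 3,4,5-trimethoxyphenyl in place of 4-cyanophenyl on a double-bonded chain carbon bound to a double-bonded ring carbon made the step of a 1.2-fold lower number from compound 1 to compound 2 (0.09 log units; within the scatter). Compound 3 differs from compound 1 by acetamido in place of fluoro on an aromatic carbon, and the values of compounds 1 and 3 sit within the scatter of one another.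

Compound 4 `COc1cc(/C=C2\CN(S(=O)(=O)c3ccc(NC(C)=O)cc3)C/C(=C\c3ccccc3F)C2=O)cc(OC)c1OC` is not yet measured in this assay. It carries the same change as that of compound 1 to compound 2, now on the core of compound 3: 3,4,5-trimethoxyphenyl in place of 4-cyanophenyl on a double-bonded chain carbon bound to a double-bonded ring carbon. The step is expected to be a 1.2-fold lower number from compound 3 to compound 4 (0.06 log units; within the scatter), which rests on compound 1 and the earlier step of a 1.2-fold lower number from compound 1 to compound 2 (0.09 log units; within the scatter). In this assay compound 4 is estimated at 12500 nM, with a range from 6000 nM to 26000 nM.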

Compound 4, half-maximal inhibitory concentration: 14000 nM
Compound 4: the middle estimate sits 1.1-fold (0.05 log units) below what was measured; the range from low to high includes it.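

In this assay the new step is a 1.0-fold lower number from compound 3 to compound 4 (0.01 log units; within the scatter), and 3,4,5-trimethoxyphenyl in place of 4-cyanophenyl reads alike on the two cores: the same change on two cores in this assay, a 1.2-fold lower number (0.09 log units; within the scatter) from compound 1 to compound 2 and a 1.0-fold lower number (0.01 log units; within the scatter) from compound 3 to compound 4, 1.2-fold (0.08 log units) apart, within the scatter of two such steps. Acetamido in place of fluoro, with a 1.3-fold lower number from compound 2 to compound 4 (0.10 log units; within the scatter), also reads alike on the two cores: the same change on two cores in this assay, a 1.5-fold lower number (0.18 log units; within the scatter) from compound 1 to compound 3 and a 1.3-fold lower number (0.10 log units; within the scatter) from compound 2 to compound 4, 1.2-fold (0.08 log units) apart, within the scatter of two such steps. Within the data shown here, every step lies within the scatter, so these four compounds show only that neither change shifts this read-out measurably on these cores, not that a shift large enough to be read would carry from one core to another.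

Going by these compounds, it stays open whether an amine or a carboxylic acid on a double-bonded chain carbon bound to a double-bonded ring carbon would give a step beyond the scatter. On these data alone, a longer chain in place of acetamido is equally open.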